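Removing the acid group: what happens to solubility

A few compounds are considered here, and "the series" means these few. Any claim that something is new, unique, unknown or untested is made for them only; others in the source may bear on it.

Two of the measured compounds carry a carboxymethyl group on an aromatic ring, and they share a similar biaryl arrangement but are built on different cores; the difference between the two cores is not broken down here. Compound 1 `O=C(O)Cc1ccc(-c2cccc(NC(=O)OCc3ccccc3)c2)cc1` and compound 2 `O=C(O)Cc1ccc(-c2ccc(CN3CC(=O)N(c4ccccc4)C3=O)cc2)cc1` were both tested in a physicochemical assay for solubility, in phosphate buffer, measured as kinetic solubility, with a stated time of 1 h, at pH 7.4; on this read-out lower numbers stand for lower solubility and higher numbers for higher solubility. In this assay compound 1 gives 198 ug/mL, and compound 2 gives 175 ug/mL, a pair of numbers that lie within the usual scatter of each other.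

Compound 3 `O=C1CN(Cc2ccc(-c3ccccc3)cc2)C(=O)N1c1ccccc1` is compound 2 with the acid group taken away. The change is hydrogen in place of carboxymethyl on an aromatic carbon. In this assay compound 3 gives 7.5 ug/mL, and the step that this change produced is a 23-fold lower number from compound 2 to compound 3 (1.37 log units; beyond the scatter).

Among the measured compounds shown here, compound 4 `O=C(Nc1cccc(-c2ccccc2)c1)OCc1ccccc1` is the matching partner for compound 1: the change from compound 1 to compound 4 is hydrogen in place of carboxymethyl on an aromatic carbon, the same change as the one from compound 2 to compound 3, at the same kind of place on the ring. For the measured compounds named here, only this single example of the change is available, so the expectation rests on one step alone. The step from compound 1 to compound 4 in this assay is expected to be a 22-fold lower number from compound 1 to compound 4 (1.34 log units; beyond the scatter), in line with the measured drop seen in a 23-fold lower number from compound 2 to compound 3 (1.37 log units; beyond the scatter). On that basis compound 4 is estimated to give 9 ug/mL in this assay, with a plausible span from 3 ug/mL to 27 ug/mL.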

Compound 4, solubility: 5 ug/mL
Estimate against measurement, compound 4: 1.8-fold (0.26 log units) above; measured number inside the range.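

In this assay the swap of hydrogen for carboxymethyl on an aromatic carbon gives a 40-fold lower number from compound 1 to compound 4 (1.60 log units; beyond the scatter), and on the other core the same swap gives a 23-fold lower number from compound 2 to compound 3 (1.37 log units; beyond the scatter), so both steps point the same way and both are large and beyond the scatter. This means that, for these two cores, a large drop seen on one core was also seen on the other, which is useful support for carrying the change across, but two matched pairs cannot show that any further core in the series would behave in the same way. Nothing shown here explains why the number drops in either pair, so the steps record what happened and not its cause.

The compounds shown leave open what happens when carboxymethyl gives way to something other than hydrogen, such as an amine, a hydroxyl group or a longer chain ending in a carboxylic acid. They also leave open whether a core unlike both of those shown here would give a step of similar size, and how the same compounds would compare on any other read-out.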